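The source may hold more compounds than are shown below. What is called first, only, known or untested is meant among the compounds shown, and "the series" means these compounds.

Compound 1 `CC(C)=CCn1c(CN2CCN(C(=O)C3CC3)CC2)nc2ccccc21`: 74.3%
Compound 2 `Cc1cccc(Cn2c(OC3CCN(C(=O)c4ccco4)CC3)nc3ccccc32)c1`: 68.3%
Compound 3 `Cc1cccc(Cn2c(CN3CCN(C(=O)C4CCCC4)CC3)nc3ccccc32)c1`: 67.5%

Of the compounds shown here, three have been tested in an assay on isolated protein for inhibition of aldehyde dehydrogenase 1A1 (Homo sapiens), read by spectrophotometry, tested at 10 uM; on this read-out higher numbers stand for more inhibition at the one concentration tested (going by the name of the read-out) and lower numbers for less inhibition. Compound 1 gives 74.3%, compound 2 gives 68.3% and compound 3 gives 67.5%. Compound 3 carries the lowest of the three numbers, yet its gaps to compound 2 and to compound 1 both lie within the scatter of repeated measurements, so no order among the three can be read from these values. Within the data shown here, no pair of the measured compounds differs in one place only, so no measured step is available to guide an expectation.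

Compound 4 `Cc1cccc(Cn2c(CN3CCN(C(=O)CC(C)C)CC3)nc3ccccc32)c1` has not yet been measured. It differs from compound 3 by isobutyl in place of cyclopentyl on a carbonyl carbon whose other neighbours are an amide-type nitrogen in a ring. Among the measured compounds shown here, nothing among the measured compounds shows how a ring-to-chain exchange at this carbonyl carbon moves the read-out, so the step is expected to be small, no larger than the scatter, in either direction. Compound 4 is therefore expected to come out near compound 3, with an estimated step of a number 3.5 percentage points lower from compound 3 to compound 4 (within the scatter). The estimate for compound 4 in this assay is 64%, with a range from 48% to 78%.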

Compound 4, a percentage reported as inhibition, at one concentration (the size of the read-out at that concentration, not a potency): 71.4%
Compound 4: the middle estimate sits 7.4 percentage points below what was measured; measured number inside the range.
By their numbers in this assay, from the lowest: compounds 3, 2, 4 and 1 (each within the scatter of the next).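

Among these compounds, this is the first measured exchange on a carbonyl carbon whose other neighbour is an amide-type nitrogen in a ring: in this assay, isobutyl in place of cyclopentyl gives a number 3.9 percentage points higher from compound 3 to compound 4 (within the scatter). The exchange removes the five-membered carbon ring and shortens the group by one heavy atom, yet the step stays within the scatter, so for this pair the ring is not needed to keep the read-out at this level at the one concentration tested. Nothing at hand explains why the two groups read alike.

The compounds shown leave open whether groups of another kind on this carbonyl carbon, such as a longer chain, a phenyl ring or a chain ending in an amine, would also stay within the scatter of compound 3, as only two carbon-only groups can be compared here. Also open, from the compounds shown here alone, is whether isobutyl and cyclopentyl would still read alike with a different group on the ring nitrogen of the shared core, and whether a single-concentration read-out hides a difference in potency between them.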